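The source may report more compounds than this note shows. Statements on the series, on what has been measured and on what is new or still open speak of the compounds shown alone.

Working notes on the series.

Compound 2 `COc1nc2ccc(Br)cc2cc1C(c1ccccc1)n1cc(-c2ccccc2)nn1` gives 5.97% in an ADME assay on PC-3 cells (Homo sapiens) for cytotoxicity, read by sulforhodamine B assay, with a stated time of 48 h, tested at 10 uM; a lower number here means less inhibition, a higher number more inhibition at the concentration tested (going by the name of the read-out). Compound 1 `COc1nc2ccc(Br)cc2cc1C(c1ccccc1)n1cc(-c2ccc(Br)cc2)nn1` gives 7.43% in this assay, and compound 3 `COc1nc2ccc(Br)cc2cc1C(c1ccccc1)n1cc(CO)nn1` gives 4.65%. Compound 2 thus stands second highest of the three numbers, with compound 3 nearest and compound 1 furthest, both within the scatter. All three numbers sit close to one another, and the series has so far shown no step beyond the scatter: a number 1.5 percentage points lower from compound 1 to compound 2 (within the scatter), a number 2.8 percentage points lower from compound 1 to compound 3 (within the scatter) and a number 1.3 percentage points lower from compound 2 to compound 3 (within the scatter).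

The next step goes to compound 4 `COc1nc2ccc(Br)cc2cc1C(c1ccccc1)n1cc(CCCCCO)nn1`, which differs from compound 2 by 5-hydroxypentyl in place of phenyl on an aromatic carbon. Among the measured compounds shown here, the step that bears most on it is the one from compound 2 to compound 3, where phenyl also leaves the same aromatic carbon and a short chain carrying a hydroxyl enters; that step was small, a number 1.3 percentage points lower from compound 2 to compound 3 (within the scatter). The step from compound 1 to compound 3, a number 2.8 percentage points lower from compound 1 to compound 3 (within the scatter), points the same way. On this basis no step beyond the scatter is expected for compound 4 in this assay, with the expected step being a number 1 percentage points lower from compound 2 to compound 4 (within the scatter).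

The estimate for compound 4 in this assay is 5%, expected to lie between 0% and 12%.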

Compound 4, a percentage reported as inhibition, at one concentration (the size of the read-out at that concentration, not a potency): 12.9%
For compound 4 the middle estimate is 7.9 percentage points below the measured one, outside the stated range (above it).
By their numbers in this assay, from the lowest: compounds 3, 2, 1 and 4 (each within the scatter of the next).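

At this aromatic carbon of the five-membered aromatic ring, 5-hydroxypentyl replaces phenyl, bringing in a chain with no ring, and the read-out in this assay shows a number 6.9 percentage points higher from compound 2 to compound 4 (within the scatter). Lengthening the hydroxyl-bearing substituent at the same carbon gives a number 8.3 percentage points higher from compound 3 to compound 4 (within the scatter), and exchanging 4-bromophenyl for 5-hydroxypentyl gives a number 5.5 percentage points higher from compound 1 to compound 4 (within the scatter), so neither the longer chain nor the loss of the aromatic ring at this carbon separates compound 4 from the other three compounds in this read-out. No measurement in hand bears on why the numbers fall as they do.

The compounds shown leave open whether an amine, a carboxylic acid or a chain longer than 5-hydroxypentyl on this carbon would give a step beyond the scatter. They also leave open whether a plain pentyl chain, without the terminal hydroxyl, would read the same as 5-hydroxypentyl in this assay on the shared core.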